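The source may hold more compounds than are shown below. What is called first, only, known or untested is meant among the compounds shown, and "the series" means these compounds.

Measured compounds:
compound 1 `O=C1NCCN1c1ccc(S(=O)(=O)Nc2cccc(Br)c2)cc1` – 59 nM
compound 2 `O=C1NCCN1c1ccc(S(=O)(=O)Nc2cccc(Oc3ccccc3)c2)cc1` – 83 nM

In a functional assay on M21 cells (Homo sapiens) for antiproliferative activity, read by sulforhodamine B assay, with a stated time of 48 h (on this read-out lower numbers stand for stronger inhibition and higher numbers for weaker inhibition), compound 1 gives 59 nM and compound 2 gives 83 nM; the step of a 1.4-fold higher number from compound 1 to compound 2 (0.15 log units; within the scatter) lies within the scatter, so the two are not separated. Compound 3 `Cc1ccc(NS(=O)(=O)c2ccc(N3CCNC3=O)cc2)c(C)c1` differs from compound 1 by 2,4-dimethylphenyl in place of 3-bromophenyl on a sulfonamide nitrogen. Going by the values given here, the one measured step touches the same aryl group on the sulfonamide nitrogen and stayed within the scatter; nothing measured addresses the 2,4-dimethylphenyl itself. A step within or near the scatter is therefore expected, and the expected step is a 1.4-fold higher number from compound 1 to compound 3 (0.13 log units; within the scatter). Compound 3 is estimated at 80 nM, with a range from 35 nM to 250 nM.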

Compound 3, half-maximal inhibitory concentration: 150 nM
Compound 3: the middle estimate sits 1.9-fold (0.27 log units) below what was measured, and the stated range covers the measured number.
By their numbers in this assay, from the lowest: compounds 1, 2 and 3 (each within the scatter of the next, the first and the last beyond it).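

In this assay, changing the aryl group on the sulfonamide nitrogen now gives a step beyond the scatter, though a modest one: a 2.5-fold higher number from compound 1 to compound 3 (0.41 log units; beyond the scatter). The earlier phenoxy in place of bromo step did not separate its pair, so this position is not indifferent to every change of aryl group. No measurement shown accounts for the step. On these data alone, whether the higher number goes with the two methyl groups or with the loss of the bromo stays open. Also open, as far as these compounds go, is how a phenyl carrying a single methyl, an amine or a carboxylic acid would read on the sulfonamide nitrogen.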